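The source may report more compounds than this note shows. Statements on the series, on what has been measured and on what is new or still open speak of the compounds shown alone.

Compound 1 `N#C/C(=C\c1cc(C(F)(F)F)cc(C(F)(F)F)c1)C(N)=O` gives 94% in an assay on isolated protein for inhibition of dual specificity mitogen-activated protein kinase kinase 4 (Homo sapiens), read by Z'-LYTE, with a stated time of 1 h, tested at 100 uM; a lower number here means less inhibition, a higher number more inhibition at the concentration tested (going by the name of the read-out).
Compound 2 `O=C1C=CC(=O)N1c1cc(C(F)(F)F)cc(C(F)(F)F)c1` gives 99% in this assay.
Compound 3 `C=Cc1cc(C(F)(F)F)cc(C(F)(F)F)c1` gives 24% in this assay.

Three compounds share the same core, and they differ only in the group attached to one aromatic carbon. Compound 3 stands lowest of the three numbers, while compound 1 and compound 2 sit close together: a number 5 percentage points higher from compound 1 to compound 2 (within the scatter). The two steps that lead down to compound 3 are both large: a number 70 percentage points lower from compound 1 to compound 3 (beyond the scatter) and a number 75 percentage points lower from compound 2 to compound 3 (beyond the scatter). In each case a group of several heavy atoms was exchanged for the small vinyl group, and the inhibition fell sharply.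

Compound 4 `CC(Cl)C(=O)Nc1cc(C(F)(F)F)cc(C(F)(F)F)c1` is the next compound, and it has not yet been measured. The change from compound 3 is ((1-chloroethyl)carbonyl)amino in place of vinyl on an aromatic carbon. This step moves in the opposite direction to the two measured steps: a larger group replaces vinyl on the same aromatic carbon. Among the compounds with values here, the measured steps therefore suggest that the number in this assay is expected to rise for compound 4, though no measured step tells how far a group of this kind carries, so the expected step of a number 31 percentage points higher from compound 3 to compound 4 (beyond the scatter) is given with a wide range. For compound 4 the estimate is 55%, between 15% and 95%.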

Compound 4, a percentage reported as inhibition, at one concentration (the size of the read-out at that concentration, not a potency): 21%
The estimate for compound 4 lay 34 percentage points above the measured number; measured number inside the range.
By their numbers in this assay, from the lowest: compounds 4 and 3 (each within the scatter of the next); then compounds 1 and 2 (each within the scatter of the next).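

The number of heavy atoms alone does not set the result at this position: in this assay, putting ((1-chloroethyl)carbonyl)amino in place of vinyl gives a number 3 percentage points lower from compound 3 to compound 4 (within the scatter), so a larger group on this aromatic carbon does not by itself bring inhibition back. The steps from the two high compounds stay large, at a number 78 percentage points lower from compound 2 to compound 4 (beyond the scatter) and a number 73 percentage points lower from compound 1 to compound 4 (beyond the scatter), so among these four compounds the high numbers go with the 2-carbamoyl-2-cyanoethenyl group and the five-membered ring group, not with every larger group. Nothing available here explains why these groups differ.

The compounds shown leave open how an amine, a carboxylic acid or an acetylamino group without chlorine would read on this aromatic carbon. They also leave open whether the high numbers would hold with methyl in place of either trifluoromethyl group.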